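A Cinnamoyl Acyl Group Replaces an Ester-Bearing Chain

This account rests on a few compounds, and the source may have more. Where it says the series, first, only, none or still open, it means among the compounds named here.

Two pyrazoline-bearing compounds have been measured so far in a functional assay on HCC1806 cells (Homo sapiens) for inhibition, read by sulforhodamine B assay, tested at 10 uM; on this read-out higher numbers stand for more inhibition at the one concentration tested (going by the name of the read-out) and lower numbers for less inhibition. Compound 1 `CN(C)c1ccc(C2CC(c3ccc(-n4cncn4)cc3)=NN2)cc1` gives 6.8% in this assay. Compound 2 `COC(=O)CC(=O)N1N=C(c2ccc(N3CCN(C)CC3)cc2)CC1c1ccc(N(C)C)cc1` gives -8.3% in this assay, the lower of the two numbers, and the gap to compound 1 lies beyond the usual scatter, so compound 2 shows the lower inhibition in this assay on the numbers shown. Among the compounds with values here, no step between two measured compounds differing in a single place is available to guide the next move.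

Compound 3 `CN1CCN(c2ccc(C3=NN(C(=O)/C=C/c4ccccc4)C(c4ccc(N(C)C)cc4)C3)cc2)CC1` follows from compound 2 by a single change at the carbonyl carbon attached to the amide-type nitrogen in the ring: 2-phenylethenyl in place of (methoxycarbonyl)methyl on a carbonyl carbon. Neither of the two measured compounds carries this acyl group. Nothing in them speaks to the effect of such a change. Compound 3 is therefore expected to sit near compound 2, with an estimated step of a number 14.3 percentage points higher from compound 2 to compound 3 (beyond the scatter) in this assay that need not exceed the scatter. The estimated value for compound 3 is 6%, within a range from -12% to 26%.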

Compound 3, a percentage reported as inhibition, at one concentration (the size of the read-out at that concentration, not a potency): 71%
Beside the measured number, compound 3's estimate is 65 percentage points below it; the whole stated range lies below it.
By their numbers in this assay, from the lowest: compound 2; then compound 1; then compound 3.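

In this assay, the acyl group on the amide-type nitrogen in the ring proves decisive, which neither earlier compound could show on its own: 2-phenylethenyl in place of (methoxycarbonyl)methyl on the carbonyl carbon gives a number 79.3 percentage points higher from compound 2 to compound 3 (beyond the scatter), a large step beyond the scatter. The entering group brings a six-membered aromatic ring of carbon only and has 0 hydrogen-bond acceptors, whereas the leaving group has no ring and 2 hydrogen-bond acceptors, but this single pair cannot separate these differences from one another. Nothing at hand bears on why the step is so large.

The compounds shown leave open whether the aromatic ring or the double bond carries the step, which a benzoyl group or a 3-phenylpropanoyl group on the same carbonyl position would help to separate, and whether a methoxy group or a chlorine on the phenyl ring of the 2-phenylethenyl group would keep it. From the compounds shown here alone, it also remains open whether the step holds with a morpholine in another part of the molecule, and, since the read-out comes from one concentration, how potent compound 3 is.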